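The source may report more compounds than this note shows. Statements on the series, on what has been measured and on what is new or still open speak of the compounds shown alone.

Working notes on the series. Among the compounds with values here, compound 3 `COC(=O)c1cccc(NC(=O)N[C@H]2CC[C@H](Oc3ccc(F)cc3)CC2)c1` gives 9200 nM in a functional assay on CRL2813 cells (Homo sapiens) for cytotoxicity, read by sulforhodamine B assay, with a stated time of 5 days (on this read-out lower numbers stand for stronger inhibition and higher numbers for weaker inhibition), the lowest of the two numbers so far; its nearest neighbour is compound 2 `Cc1cccc(NC(=O)N[C@H]2CC[C@H](Oc3ccc(F)cc3)CC2)c1` at 14400 nM, a gap inside the scatter. Compound 1 `O=C(Nc1ccc(Br)cc1)N[C@H]1CC[C@H](Oc2ccc(F)cc2)CC1` returns only a limit of the assay, > 20000 nM, as noted in the limit of > 20000 nM in this assay, at which 1 of the 3 values shown sits. Compound 4 `O=C(Nc1cccc(I)c1)N[C@H]1CC[C@H](Oc2ccc(F)cc2)CC1` carries iodo in place of methoxycarbonyl on an aromatic carbon. The measured steps bearing on this are an at least 1.3-fold lower number from compound 1 to compound 2 (0.14 log units; that floor lies within the scatter) and a 1.6-fold lower number from compound 2 to compound 3 (0.19 log units; within the scatter), neither beyond the scatter, so the aryl substituent has so far moved the read-out little. A step of the same small size is expected, with no clear direction: compound 4 is estimated at 12000 nM, from 5000 nM to 30000 nM. The estimated step is therefore a 1.3-fold higher number from compound 3 to compound 4 (0.12 log units; within the scatter), a change expected to stay within the scatter.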

Compound 4, half-maximal inhibitory concentration: 5200 nM
Beside the measured number, compound 4's estimate is 2.3-fold (0.36 log units) above it, within the range that was stated.
By their numbers in this assay, from the lowest: compounds 4, 3 and 2 (each within the scatter of the next, the first and the last beyond it). At a limit, above all of these: compound 1.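

Iodo on this aromatic carbon brings the first steps beyond the scatter in the series: a 2.8-fold lower number from compound 2 to compound 4 (0.44 log units; beyond the scatter) in place of methyl, and an at least 3.8-fold lower number from compound 1 to compound 4 (0.58 log units; beyond the scatter) with 3-iodophenyl in place of 4-bromophenyl. Against methoxycarbonyl the change stays inside the scatter (a 1.8-fold lower number from compound 3 to compound 4 (0.25 log units; within the scatter)), so iodo and methoxycarbonyl are not separated here. The step from compound 1 is only a floor, compound 1 standing at a limit: the limit of > 20000 nM in this assay, at which 1 of the 4 values shown sits.

On these data alone, how an amine or a carboxylic acid on this aromatic carbon would read out stays open, as does whether any group here gives much stronger inhibition.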